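The source may report more compounds than this note shows. Statements on the series, on what has been measured and on what is new or still open speak of the compounds shown alone.

Measured in a functional assay on MV4-11 cells (Homo sapiens) for inhibition, read by resazurin assay, with a stated time of 72 h; on this read-out lower numbers stand for stronger inhibition of growth and higher numbers for weaker inhibition of growth:
- compound 1 `Cc1csc(-c2cncc(Cl)c2N2CCC3(CCNC3=O)CC2)c1`: 650 nM
- compound 2 `Cc1cc(-c2cncc(Cl)c2N2CCC3(CCNC3=O)CC2)sc1C=O`: 2530 nM
- compound 3 `O=Cc1cc(-c2cncc(Cl)c2N2CCC3(CCNC3=O)CC2)cs1`: 730 nM

Compound 3, at 730 nM, lies within the scatter of compound 1 and well under compound 2. Next is compound 4 `O=C1NCCC12CCN(c1c(Cl)cncc1-c1cn[nH]c1)CC2`, with 1H-pyrazol-4-yl in place of 5-formylthiophen-3-yl on an aromatic carbon.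

Among the measured compounds shown here, three measured steps bear on this change. Exchanging the whole thiophene group gave a 1.1-fold higher number from compound 1 to compound 3 (0.05 log units; within the scatter), while the other exchange gave a 3.5-fold lower number from compound 2 to compound 3 (0.54 log units; beyond the scatter). Adding a formyl in place of hydrogen gave a 3.9-fold higher number from compound 1 to compound 2 (0.59 log units; beyond the scatter). None of these compounds carries a pyrazole, so the data do not fix a direction. For the measured compounds named here, the closest precedent is compound 1 with a 1.1-fold higher number from compound 1 to compound 3 (0.05 log units; within the scatter), so no step beyond the scatter is expected, with a modest step in either direction still possible. The expected change is a 1.2-fold higher number from compound 3 to compound 4 (0.09 log units; within the scatter). For compound 4 the estimated value is 900 nM, with an expected range of 250 nM to 3000 nM.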

Compound 4, concentration for 50% growth inhibition: 8520 nM
Estimate against measurement, compound 4: 9.5-fold (0.98 log units) below; the measured number lies above the stated range.
By their numbers in this assay, from the lowest: compounds 1 and 3 (each within the scatter of the next); then compound 2; then compound 4.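

In this assay this position on the shared core proves far less tolerant than the thiophene groups suggested, with 1H-pyrazol-4-yl giving a 12-fold higher number from compound 3 to compound 4 (1.07 log units; beyond the scatter) and a 13-fold higher number from compound 1 to compound 4 (1.12 log units; beyond the scatter) in the first large steps seen here. Even the formyl- and methyl-bearing thiophene of compound 2, the weakest of the earlier three, is better than the pyrazole, with a 3.4-fold higher number from compound 2 to compound 4 (0.53 log units; beyond the scatter) and compound 4 now the weakest of the four. The entering ring brings a hydrogen-bond donor that the thiophene groups lack, but no measurement available here connects that difference or any other to the loss.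

Open, on these data alone, is whether the loss follows the ring hydrogen on nitrogen or the pyrazole ring itself. A 1-methyl-1H-pyrazol-4-yl or a plain phenyl group on the same carbon would separate these two readings.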